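Shortening the phenyl-tipped chain on a shared core

The compounds below may be only part of what the source reports. "The series", "measured", "known", "first", "only" and "open" are said of these compounds alone.

Compound 1 `O=C(CCCCc1ccccc1)CC(=O)N[C@H]1CCOC1=O`, compound 2 `O=C(CCCc1ccccc1)CC(=O)N[C@H]1CCOC1=O` and compound 3 `O=C(CCCCCCCCCc1ccccc1)CC(=O)N[C@H]1CCOC1=O` share one core and differ only in the length of the chain that carries the phenyl ring. In a functional assay on NCI-H630 cells (Homo sapiens) for cytotoxicity, read by sulforhodamine B assay, with a stated time of 5 days (on this read-out lower numbers stand for stronger inhibition and higher numbers for weaker inhibition), compound 1 returns only a limit of the assay, > 100000 nM. Compound 2 likewise returns only a limit in this assay, > 100000 nM. For the measured compounds named here, compound 3 is the single member with a number in this assay, 16000 nM. The change from compound 1 to compound 2 is phenyl in place of benzyl on a saturated chain carbon, three bonds along the chain from a carbonyl carbon, and the step that the two limits leave unreadable from compound 1 to compound 2 cannot be sized because of the limit of > 100000 nM in this assay, at which 2 of the 3 values shown sit. How the core of compound 3 differs from that of compound 1 is not broken down here.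

Compound 4 `O=C(CCCCCCCCc1ccccc1)CC(=O)N[C@H]1CCOC1=O` has not been measured. It arises from compound 3 by phenyl in place of benzyl on a saturated chain carbon, eight bonds along the chain from a carbonyl carbon, the same kind of change as that from compound 1 to compound 2, but placed eight bonds rather than three bonds along the chain from the carbonyl carbon. As the earlier step gives no readable size, the expectation rests on compound 3 alone, whose 16000 nM is the only anchor. The step from compound 3 to compound 4 is expected to be small, a 1.6-fold higher number from compound 3 to compound 4 (0.19 log units; within the scatter), leaning toward weaker inhibition. Compound 4 is therefore estimated at 25000 nM in this assay, most likely between 9000 nM and 100000 nM.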

Compound 4, half-maximal inhibitory concentration: 11000 nM
Compound 4: middle estimate off by 2.3-fold (0.36 log units), on the high side; the measured number falls inside the stated range.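

In this assay, phenyl in place of benzyl on a saturated chain carbon, eight bonds along the chain from a carbonyl carbon, gives a 1.5-fold lower number from compound 3 to compound 4 (0.16 log units; within the scatter), so on the core of compound 3 the change leaves the read-out unmoved as far as the scatter allows. The same kind of change on the core of compound 1, three bonds along the chain from a carbonyl carbon, cannot be set beside this result, and its step cannot be read because both of its compounds return only a limit: the limit of > 100000 nM in this assay, at which 2 of the 4 values shown sit. The series therefore holds one readable step, which shows that the change is tolerated on the core of compound 3 but does not show whether it carries over to another core, or how large it would be there.

The compounds shown leave open at which chain length between those of compound 2 and compound 4 the read-out in this assay first moves off the limit, and whether a longer chain than that of compound 3 would change the number. Also open, on these data alone, is what an amine or a carboxylic acid at the chain end, in place of the phenyl ring, would do.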